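Compound 3 to compound 4: expected step on the aryl swap

This account rests on a few compounds, and the source may have more. Where it says the series, first, only, none or still open, it means among the compounds named here.

In a functional assay on MDA-MB-231 cells (Homo sapiens) for antiproliferative activity, read by MTT assay, with a stated time of 72 h (on this read-out higher numbers stand for weaker inhibition and lower numbers for stronger inhibition), compound 1 (`CC1=CC[C@H]2[C@H](CC[C@]2(C)O)C(C)(C)[C@@H]1CC[C@H]1[C@]2(C)CC[C@H](OC(=O)CCC(=O)O)C(C)(C)O[C@H]2CC[C@@]1(C)O`) gives 27900 nM, compound 2 (`CC1=CC[C@H]2[C@H](CC[C@]2(C)O)C(C)(C)[C@@H]1CC[C@H]1[C@]2(C)CC[C@H](OC(=O)c3ccc(Cl)cc3)C(C)(C)O[C@H]2CC[C@@]1(C)O`) gives 10300 nM and compound 3 (`CC1=CC[C@H]2[C@H](CC[C@]2(C)O)C(C)(C)[C@@H]1CC[C@H]1[C@]2(C)CC[C@H](OC(=O)NCc3ccccc3)C(C)(C)O[C@H]2CC[C@@]1(C)O`) gives 40300 nM. Compound 3 shares the high end of these numbers, as a 1.4-fold higher number from compound 1 to compound 3 (0.16 log units; within the scatter) is no real separation. Only compound 2 stands clearly apart.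

The next change leads to compound 4 (`CC1=CC[C@H]2[C@H](CC[C@]2(C)O)C(C)(C)[C@@H]1CC[C@H]1[C@]2(C)CC[C@H](OC(=O)c3ccc(Cl)c(Cl)c3)C(C)(C)O[C@H]2CC[C@@]1(C)O`): 3,4-dichlorophenyl in place of benzylamino on a carbonyl carbon. The closest evidence is a 3.9-fold higher number from compound 2 to compound 3 (0.59 log units; beyond the scatter), which exchanges 4-chlorophenyl for the same benzylamino at the same place. Read backwards, that step points to a lower number for an aryl group at this carbonyl carbon. In agreement, a 2.7-fold lower number from compound 1 to compound 2 (0.43 log units; beyond the scatter) also favours 4-chlorophenyl, this time over 2-carboxyethyl. Within the data shown here, no measured pair compares 3,4-dichlorophenyl with 4-chlorophenyl, so the value of compound 2 serves as the anchor and the range is kept wide.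

A modest step to a lower number is therefore expected in this assay, an estimated 4.5-fold lower number from compound 3 to compound 4 (0.65 log units; beyond the scatter). For compound 4 the estimate is 9000 nM, with an expected range from 4000 nM to 21000 nM.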

Compound 4, half-maximal inhibitory concentration: 8100 nM
Compound 4: middle estimate off by 1.1-fold (0.05 log units), on the high side, and the stated range covers the measured number.
By their numbers in this assay, from the lowest: compounds 4 and 2 (each within the scatter of the next); then compounds 1 and 3 (each within the scatter of the next).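

In this assay the lower numbers at this carbonyl carbon no longer rest on 4-chlorophenyl alone: 3,4-dichlorophenyl gives a 5.0-fold lower number from compound 3 to compound 4 (0.70 log units; beyond the scatter) against benzylamino and a 3.4-fold lower number from compound 1 to compound 4 (0.54 log units; beyond the scatter) against 2-carboxyethyl, and both steps lie beyond the scatter. The second chlorine adds no separable effect, since chloro in place of hydrogen on the aromatic carbon gives a 1.3-fold lower number from compound 2 to compound 4 (0.10 log units; within the scatter) and leaves the two chlorinated aryl compounds on one level within the scatter. Across the four compounds, the two groups with a chlorinated aromatic ring attached directly to the carbonyl carbon sit apart from benzylamino and 2-carboxyethyl, while the latter two remain within the scatter of each other, and no measurement at hand accounts for this difference.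

As far as these compounds go, it remains open whether unsubstituted phenyl on the same carbonyl carbon would stay level with the chlorinated aryl groups, which would show whether chlorine is needed at all. Also open, from the compounds shown here alone, is how anilino, which keeps the amide hydrogen but lacks the benzylic carbon, or a simple amine-bearing alkyl chain would compare with benzylamino and 2-carboxyethyl at this place.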